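The source may report more compounds than this note shows. Statements on the series, on what has been measured and on what is new or still open speak of the compounds shown alone.

Measured in an assay on cell membranes for displacement of a labelled ligand from Neuronal acetylcholine receptor; alpha4/beta2 (Rattus norvegicus) (on this read-out higher numbers stand for weaker inhibition and lower numbers for stronger inhibition), so far:
compound 1 `Oc1ccc(Nc2ccc(N3CC4CC(C3)N4)cn2)cc1`: 7.1 nM
compound 2 `Cc1ccc(Nc2ccc(N3CC4CC(C3)N4)cn2)cc1`: 52.1 nM

Within the data shown here, compound 2 stands highest of these two numbers; the only step known is a 7.3-fold higher number from compound 1 to compound 2 (0.87 log units; beyond the scatter), methyl in place of hydroxy on an aromatic carbon. Compound 3 `Fc1ccc(Nc2ccc(N3CC4CC(C3)N4)cn2)cc1` differs from compound 2 by fluoro in place of methyl on an aromatic carbon. Among the measured compounds shown here, no measured step exchanges methyl for fluoro, and the hydroxy-to-methyl step a 7.3-fold higher number from compound 1 to compound 2 (0.87 log units; beyond the scatter) bears on it only indirectly, so in this assay any expected move is small. Compound 3 is estimated at 30 nM, with a range from 10 nM to 90 nM. That expected step, a 1.7-fold lower number from compound 2 to compound 3 (0.24 log units; within the scatter), lies within the scatter.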

Compound 3, inhibition constant: 2.38 nM
Compound 3: the middle estimate sits 13-fold (1.10 log units) above what was measured, outside the stated range (below it).
By their numbers in this assay, from the lowest: compound 3; then compound 1; then compound 2.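

At the aromatic carbon para to a large group, this assay is sensitive to the exchange of a single heavy atom: fluoro in place of methyl gives a 22-fold lower number from compound 2 to compound 3 (1.34 log units; beyond the scatter). A hydroxy group is not required here for a low number, since fluoro in place of hydroxy gives a 3.0-fold lower number from compound 1 to compound 3 (0.47 log units; beyond the scatter). No available evidence accounts for either step.

From the compounds shown here alone, how chloro, methoxy, trifluoromethyl or an amine would compare at this position remains open. Also open, going by these compounds, is whether fluoro would give a similar result elsewhere on this ring.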